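Swapping the aryl group on a glucagon receptor series

The compounds below may be only part of what the source reports. "The series", "measured", "known", "first", "only" and "open" are said of these compounds alone.

Measured so far in an assay on CHO cells for inhibition of Glucagon receptor (Homo sapiens), tested at 20 uM; on this read-out lower numbers stand for less inhibition and higher numbers for more inhibition at the one concentration tested (going by the name of the read-out):
compound 1 `CCCCCc1c(C(C)C)nc(C(C)C)c(CO)c1-c1ccc(CC)cc1`: 42%
compound 2 `CCC/C=C/c1c(C(C)C)nc(C(C)C)c(CO)c1-c1ccc(Cl)c(Cl)c1`: 39%
compound 3 `CCCCCc1c(C(C)C)nc(C(C)C)c(CO)c1-c1ccc2ccccc2c1`: 16%

These three share one core and differ only in the aryl group attached to it. Compound 1 stands highest of the three numbers; compound 2 lies within the usual scatter of it, whereas compound 3 sits well below it, beyond the scatter. Compound 4 `CCCCCc1c(C(C)C)nc(C(C)C)c(CO)c1-c1ccccc1C` has not been measured. It differs from compound 1 in one place: 2-methylphenyl in place of 4-ethylphenyl on an aromatic carbon. Among the compounds with values here, no pair of measured compounds isolates this change, so the expectation rests only on the spread of the three values. In this assay a modest downward step is expected, a number 12 percentage points lower from compound 1 to compound 4 (beyond the scatter), one that could still fall within the scatter. Compound 4 is therefore estimated at 30%, within 10% to 52%.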

Compound 4, a percentage reported as inhibition, at one concentration (the size of the read-out at that concentration, not a potency): 33%
Compound 4: the middle estimate sits 3 percentage points below what was measured; the range from low to high includes it.
By their numbers in this assay, from the lowest: compound 3; then compounds 4, 2 and 1 (each within the scatter of the next).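

In this assay, 2-methylphenyl in place of 4-ethylphenyl gives a number 9 percentage points lower from compound 1 to compound 4 (within the scatter) on the shared core. Within the data shown here, this pair isolates one change at this position, which the earlier compounds did not do, and the two numbers cannot be told apart here even though the methyl and ethyl groups sit at different places on the phenyl ring. Nothing available explains why these two aryl groups read alike. Still open, going by these compounds, is how a phenyl ring carrying an amine or a carboxylic acid would read, and whether a longer chain in place of the ethyl group would hold the number.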